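The compounds below may be only part of what the source reports. "The series", "measured", "known", "first", "only" and "open" are said of these compounds alone.

Two compounds share one core. Compound 1 `NS(=O)(=O)c1ccc2nc(-n3nc(C(F)(F)F)cc3-c3ccc(Cl)cc3)sc2c1` gives in a functional assay on the whole organism (strain Wistar albino) for inhibition, with Rattus norvegicus as the target, read by paw edema, with stated times of 30 min and 2 h, at a dose of 50 mg/kg by the oral route (on this read-out higher numbers stand for more inhibition at the one dose given (going by the name of the read-out) and lower numbers for less inhibition), a value of 42%, and compound 2 `NS(=O)(=O)c1ccc2nc(-n3nc(C(F)(F)F)cc3-c3ccco3)sc2c1` gives in this assay a value of 46%. The step of a number 4 percentage points higher from compound 1 to compound 2 (within the scatter) lies within the scatter, so the two stand level rather than ranked; compound 2 holds the higher of the two numbers, but its gap to compound 1 is within the scatter. Compound 3 `NS(=O)(=O)c1ccc2nc(-n3nc(C(F)(F)F)cc3-c3ccc4ccccc4c3)sc2c1` carries the change (naphthalen-2-yl in place of furan-2-yl on an aromatic carbon), with the entering group sitting on the aromatic carbon next to the ring nitrogen. Going by the values given here, the only measured step, a number 4 percentage points higher from compound 1 to compound 2 (within the scatter), also exchanged the group at this carbon and stayed within the scatter. Among the compounds with values here, no measured step involves naphthalen-2-yl. The step of a number 2 percentage points lower from compound 2 to compound 3 (within the scatter) is therefore expected to lie within the scatter. The estimate for compound 3 in this assay is 44%, within a range from 30% to 58%.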

Compound 3, a percentage reported as inhibition, in the whole organism at one dose (the size of the read-out at that dose, not a potency): 27%
Compound 3: the middle estimate sits 17 percentage points above what was measured; the measured number lies below the stated range.
By their numbers in this assay, from the lowest: compound 3; then compounds 1 and 2 (each within the scatter of the next).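

In this assay, the aromatic carbon next to the ring nitrogen proves not to be indifferent to the group it carries: naphthalen-2-yl gives a number 19 percentage points lower from compound 2 to compound 3 (beyond the scatter) and a number 15 percentage points lower from compound 1 to compound 3 (beyond the scatter). The earlier exchange at this carbon, a number 4 percentage points higher from compound 1 to compound 2 (within the scatter), had shown no separation between furan-2-yl and 4-chlorophenyl, so among these three compounds only naphthalen-2-yl stands apart. Nothing given here accounts for this drop in inhibition of paw edema.

From the compounds shown here alone, it remains open whether other groups at this carbon, such as a methyl group, a cyclohexyl ring or a phenyl ring bearing a carboxylic acid or an amine, would stay level with compound 1 and compound 2 or fall with compound 3. With a single oral dose, these numbers also leave the compounds' potency open.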